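The compounds below may be only part of what the source reports. "The series", "measured", "known", "first", "only" and "open" are said of these compounds alone.

Compound 1, `Brc1cn2ccnc2c(-c2ccc3ncn(C4CCCCC4)c3c2)n1`, gives 26.3%.
Compound 2, `Fc1ccc(-c2cn3ccnc3c(-c3ccc4ncn(C5CCCCC5)c4c3)n2)cc1`, gives 25.2%.
Compound 3, `Brc1ccc(-c2cn3ccnc3c(-c3ccc4ncn(C5CCCCC5)c4c3)n2)cc1`, gives 20.4%.

These three numbers come from a functional assay on MOLT-4 cells (Homo sapiens) for inhibition, read by sulforhodamine B assay, with a stated time of 48 h, tested at 10 uM; on this read-out higher numbers stand for more inhibition at the one concentration tested (going by the name of the read-out) and lower numbers for less inhibition. Compound 2 gives the second highest of the three, although all three lie within the scatter of one another: the step of a number 1.1 percentage points lower from compound 1 to compound 2 (within the scatter) and the step of a number 4.8 percentage points lower from compound 2 to compound 3 (within the scatter) are both small, and the step of a number 5.9 percentage points lower from compound 1 to compound 3 (within the scatter) is small as well.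

Compound 4, `FC(F)(F)c1cccc(-c2cn3ccnc3c(-c3ccc4ncn(C5CCCCC5)c4c3)n2)c1`, has not been measured. It differs from compound 2 in one place: 3-(trifluoromethyl)phenyl in place of 4-fluorophenyl on an aromatic carbon. Going by the values given here, no measured step exchanges one aryl group for another of this kind, so none bears on it directly. The nearest is the exchange within the aryl group from compound 2 to compound 3, which stayed within the scatter, as did the two exchanges of bromo for an aryl group. The step of a number 2.2 percentage points lower from compound 2 to compound 4 (within the scatter) is therefore expected to stay within the scatter in this assay. Compound 4 is expected to give 23%, with a range from 10% to 36%.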

Compound 4, a percentage reported as inhibition, at one concentration (the size of the read-out at that concentration, not a potency): 32.9%
Compound 4: middle estimate off by 9.9 percentage points, on the low side, and the stated range covers the measured number.
By their numbers in this assay, from the lowest: compounds 3, 2, 1 and 4 (each within the scatter of the next, the first and the last beyond it).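

In this assay, going by these compounds alone, the 3-(trifluoromethyl)phenyl group gives the first exchange at this position that goes beyond the scatter: a number 12.5 percentage points higher from compound 3 to compound 4 (beyond the scatter), a modest step. Within the data shown here, the same group does not separate from the other two substituents, since a number 7.7 percentage points higher from compound 2 to compound 4 (within the scatter) and a number 6.6 percentage points higher from compound 1 to compound 4 (within the scatter) both stay within the scatter, so only this one pair is told apart at this position. Nothing measured here bears on why this pair separates.

The groups 4-bromophenyl and 3-(trifluoromethyl)phenyl differ both in the substituent and in its place on the phenyl ring, so the compounds shown cannot say which of the two accounts for the step. As far as these compounds go, it also remains open how an unsubstituted phenyl, or a phenyl carrying an amine or a carboxylic acid, would read at this position.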